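A few compounds are considered here, and "the series" means these few. Any claim that something is new, unique, unknown or untested is made for them only; others in the source may bear on it.

Compound 1 `CCOC(=O)c1sc(-c2nc3ccccc3n2C)nc1C` gives 13900 nM in a functional assay on SMMC-7721 cells (Homo sapiens) for cytotoxicity, read by MTT assay, with a stated time of 24 h; a lower number here means a stronger inhibitor, a higher number a weaker inhibitor.
Compound 2 `CCOC(=O)c1sc(-c2nc3ccccc3n2CC)nc1C` gives 9850 nM.
Compound 3 `CCOC(=O)c1sc(-c2nc3ccccc3n2Cc2ccccc2)nc1C` gives 2780 nM.

Compound 3 stands lowest of the three numbers: a 3.5-fold lower number from compound 2 to compound 3 (0.55 log units; beyond the scatter) and a 5.0-fold lower number from compound 1 to compound 3 (0.70 log units; beyond the scatter), both beyond the scatter, whereas a 1.4-fold lower number from compound 1 to compound 2 (0.15 log units; within the scatter) stays within it. Compound 4 `Cc1nc(-c2nc3ccccc3n2Cc2ccccc2)sc1C(=O)Nc1ccccc1` differs from compound 3 by anilino in place of ethoxy on a carbonyl carbon. For the measured compounds named here, none of the measured steps bears on this change: all three concern the group on the saturated chain carbon bound to the aromatic nitrogen, and the carbonyl substituent is the same in compounds 1, 2 and 3. No direction can be read from them, so the step of a 1.1-fold lower number from compound 3 to compound 4 (0.05 log units; within the scatter) is expected to stay within the scatter, with a wide margin of uncertainty. Compound 4 is therefore estimated at 2500 nM, with a range from 600 nM to 10000 nM.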

Compound 4, half-maximal inhibitory concentration: 3700 nM
Compound 4: middle estimate off by 1.5-fold (0.17 log units), on the low side; the measured number falls inside the stated range.
By their numbers in this assay, from the lowest: compounds 3 and 4 (each within the scatter of the next); then compounds 2 and 1 (each within the scatter of the next).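

At the carbonyl carbon, where compounds 1, 2 and 3 all carry the same group, anilino in place of ethoxy gives a 1.3-fold higher number from compound 3 to compound 4 (0.12 log units; within the scatter) in this assay. This position therefore accepts an aromatic ring and an amide hydrogen in place of ethoxy without a shift beyond the scatter. No evidence on the reason for this result is available. As far as these compounds go, whether a carboxylic acid or a morpholine amide at this carbonyl carbon would behave the same remains open. So does the effect of a chlorine or methoxy group on the anilino ring.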